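The compounds below may be only part of what the source reports. "The series", "measured", "known", "first", "only" and "open" are said of these compounds alone.

Measured in a functional assay on K562 cells (Homo sapiens) for cytotoxicity, read by MTT assay; a higher number here means that more compound is tolerated, a lower number that less compound is tolerated:
- Compound 1 `C/C(=C/CC[C@@H](C)CC(=O)O)CC/C=C(/C)CCCc1ccoc1`: > 100 ug/mL
- Compound 2 `CC1=C(O)/C(=C/[C@H](C)CC/C=C(/C)CC/C=C(/C)CCCc2ccoc2)OC1=O`: 62 ug/mL

Not yet measured: compound 3 `C/C(=C/CC[C@@H](C)CC(=O)O)CC/C=C(/C)CCCC1=CC(=O)OC1=O`.

Compound 1 stands only at a limit of this assay, > 100 ug/mL, and not at a number.

Compound 3 keeps the chain and acid end of compound 1 but carries a new group in place of the furan-3-yl, on a saturated chain carbon, three bonds along the chain from a double-bonded chain carbon: a group of 7 heavy atoms (4 carbon, 3 oxygen; one five-membered non-aromatic ring with 1 hetero atom) in place of a group of 5 heavy atoms (4 carbon, 1 oxygen; one five-membered aromatic ring with 1 hetero atom), on a saturated chain carbon, three bonds along the chain from a double-bonded chain carbon. Among the compounds with values here, no measured step touches this place. Within the data shown here, the only measured step, an at least 1.6-fold lower number from compound 1 to compound 2 (0.20 log units; that floor lies within the scatter), keeps the furan-3-yl and changes a saturated chain carbon bound to two saturated chain carbons, so it offers only a weak guide. No step beyond the scatter is therefore expected in this assay, and a reading at the limit remains possible. The expected step is an at least 1.2-fold lower number from compound 1 to compound 3 (0.09 log units; that floor lies within the scatter). For compound 3 the estimated value is 80 ug/mL, with an expected range of 30 ug/mL to 160 ug/mL.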

Compound 3, concentration lethal to 50% of the cells: > 100 ug/mL
Compound 3 was reported as a limit (the forecaster's own chance of this, stated with the estimate: 50%); at least 1.2-fold (0.09 log units) between middle value and limit.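

No step can be read between compound 1 and compound 3 in this assay, as both values are limits and not numbers: the limit of > 100 ug/mL in this assay, at which 2 of the 3 values shown sit.

The compounds shown leave open whether replacing the furan-3-yl with the non-aromatic five-membered ring of compound 3 changes this read-out at all.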